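A few compounds are considered here, and "the series" means these few. Any claim that something is new, unique, unknown or untested is made for them only; others in the source may bear on it.

Compound 2 `COc1cc(-c2nnc3n2NC(c2ccco2)C(C(=O)c2cccs2)S3)cc(OC)c1OC` and compound 1 `COc1cc(C(=O)C2Sc3nnc(-c4cc(OC)c(OC)c(OC)c4)n3NC2c2ccco2)cc(OC)c1OC` share one core and differ only in the group on the carbonyl carbon. In a functional assay on PC-3 cells (Homo sapiens) for cytotoxicity, read by MTT assay, with a stated time of 48 h (a lower number here means a stronger inhibitor, a higher number a weaker inhibitor), compound 2 gives 46200 nM, and compound 1 gives 52200 nM; the step of a 1.1-fold lower number from compound 1 to compound 2 (0.05 log units; within the scatter) lies within the scatter, so the two numbers cannot be ordered. Compound 3 `COc1cc(-c2nnc3n2NC(c2ccco2)C(C(=O)c2ccc(F)cc2)S3)cc(OC)c1OC` carries the change (4-fluorophenyl in place of thiophen-2-yl on a carbonyl carbon). For the measured compounds named here, the only comparable exchange at this carbonyl carbon, from compound 1 to compound 2, left this assay essentially unchanged, so no step beyond the scatter is expected; the expected step is a 1.0-fold lower number from compound 2 to compound 3 (0.00 log units; within the scatter). Compound 3 is therefore estimated at 46000 nM, with a range from 20000 nM to 110000 nM.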

Compound 3, half-maximal inhibitory concentration: 27700 nM
Beside the measured number, compound 3's estimate is 1.7-fold (0.22 log units) above it; measured number inside the range.
By their numbers in this assay, from the lowest: compounds 3, 2 and 1 (each within the scatter of the next).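

In this assay, the exchange for 4-fluorophenyl gives a 1.7-fold lower number from compound 2 to compound 3 (0.22 log units; within the scatter) and a 1.9-fold lower number from compound 1 to compound 3 (0.28 log units; within the scatter) and so does not separate compound 3 from either earlier compound. This position on the carbonyl carbon has now taken three different aromatic groups with no step beyond the scatter, and compounds 1, 2 and 3 cannot be ordered. No measurement offers an explanation for these numbers. On these data alone, whether an amine or a carboxylic acid on this carbonyl carbon would shift this assay beyond the scatter remains open.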